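A few compounds are considered here, and "the series" means these few. Any claim that something is new, unique, unknown or untested is made for them only; others in the source may bear on it.

Compound 1 `C#C[C@@]1(O)[C@@H](CO)O[C@@H](n2cc(Br)c3c(Cl)ccnc32)[C@@H]1O` – 890 nM
Compound 2 `C#C[C@@]1(O)[C@@H](CO)O[C@@H](n2cc(I)c3c(Cl)ccnc32)[C@@H]1O` – 1100 nM

Among the measured compounds shown here, in a functional assay on HeLa cells (Homo sapiens) for antiproliferative activity, read by cell counting, with a stated time of 72 h (on this read-out higher numbers stand for weaker inhibition and lower numbers for stronger inhibition), compound 2 gives 1100 nM and stands level with compound 1, its only measured neighbour. For the measured compounds named here, the one measured step is a 1.2-fold higher number from compound 1 to compound 2 (0.09 log units; within the scatter) and it comes from iodo in place of bromo on an aromatic carbon. Next comes compound 3 `C#C[C@@]1(O)[C@@H](CO)O[C@@H](n2ccc3c(Cl)ccnc32)[C@@H]1O` with this change: hydrogen in place of iodo on an aromatic carbon or, in words, hydrogen in place of iodo on an aromatic carbon. The measured step only swapped one halogen for another. Here the halogen goes altogether, and no measured compound shows what that does, so the step offers weak guidance. A modest loss of inhibition in this assay is expected, though this is a cautious guess. The estimated change is a 2.3-fold higher number from compound 2 to compound 3 (0.36 log units; beyond the scatter) as a best guess. Compound 3 is estimated at 2500 nM with an expected range from 600 nM to 10000 nM in this measurement.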

Compound 3, half-maximal inhibitory concentration: 135000 nM
Estimate against measurement, compound 3: 54-fold (1.73 log units) below; the whole stated range lies below it.
By their numbers in this assay, from the lowest: compounds 1 and 2 (each within the scatter of the next); then compound 3.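

Exchanging one halogen for another on this aromatic carbon revealed little, but removing the halogen altogether has a very large effect in this assay: taking away the iodo group gives a 120-fold higher number from compound 2 to compound 3 (2.09 log units; beyond the scatter) and taking away the bromo group gives a 150-fold higher number from compound 1 to compound 3 (2.18 log units; beyond the scatter). This carbon of the five-membered aromatic ring is therefore far from indifferent to what it carries, since bromo and iodo lie within the scatter of each other while hydrogen gives a far higher number, meaning much weaker inhibition. Nothing available explains why the number climbs so steeply. As far as these compounds go, whether only a halogen can serve here remains open. A methyl group, an amine or a nitrile on the same carbon would show whether groups other than bromo and iodo can keep the stronger inhibition.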